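Trifluoromethoxy on compound 1 in a flat series

A few compounds are considered here, and "the series" means these few. Any claim that something is new, unique, unknown or untested is made for them only; others in the source may bear on it.

Measured in a functional assay on HL-60 cells (Homo sapiens) for cytotoxicity, read by WST assay, with a stated time of 48 h; a higher number here means that more compound is needed for the effect, a lower number that less compound is needed:
Compound 1 `O=C1OC[C@H](Cc2ccccc2)[C@H]1Cc1ccccc1` gives 77000 nM
Compound 2 `COc1ccccc1C[C@H]1C(=O)OC[C@@H]1Cc1ccccc1` gives 79000 nM
Compound 3 `O=C1OC[C@H](Cc2ccccc2)[C@H]1Cc1ccccc1F` gives 72000 nM

Compound 1 has no distinct place among these three, whose values all lie within the scatter of one another. The change now in question leads to compound 4 `O=C1OC[C@H](Cc2ccccc2)[C@H]1Cc1ccc(OC(F)(F)F)cc1` and is trifluoromethoxy in place of hydrogen on an aromatic carbon with trifluoromethoxy in place of hydrogen on an aromatic carbon, para to a large group. Among the compounds with values here, two measured steps bear on it. Methoxy in place of hydrogen gave a 1.0-fold higher number from compound 1 to compound 2 (0.01 log units; within the scatter) and fluoro in place of hydrogen gave a 1.1-fold lower number from compound 1 to compound 3 (0.03 log units; within the scatter) in this assay. Neither step involves trifluoromethoxy, so they serve only as a guide, and the data do not show how this larger group will behave. On that guide, no step beyond the scatter is expected in this assay and the expected step is a 1.3-fold lower number from compound 1 to compound 4 (0.11 log units; within the scatter) in size. For compound 4 the estimated value is 60000 nM with an expected range (25000 nM to 100000 nM).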

Compound 4, half-maximal effective concentration: 27000 nM
Compound 4: middle estimate off by 2.2-fold (0.35 log units), on the high side; measured number inside the range.
By their numbers in this assay, from the lowest: compound 4; then compounds 3, 1 and 2 (each within the scatter of the next).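

In this assay, trifluoromethoxy on an aromatic carbon, para to a large group, gave a 2.9-fold lower number from compound 1 to compound 4 (0.46 log units; beyond the scatter), the only step among these compounds to pass beyond the scatter. The earlier steps shown here, a 1.0-fold higher number from compound 1 to compound 2 (0.01 log units; within the scatter) and a 1.1-fold lower number from compound 1 to compound 3 (0.03 log units; within the scatter), had left the series flat, so compound 4 shows that a change on this ring of compound 1 can move the number, though only modestly. Nothing available explains this step.

The compounds shown leave open whether the step belongs to trifluoromethoxy itself or to its place, since methoxy and fluoro appear only elsewhere on the ring. They also leave open how a trifluoromethyl group, a nitrile or a carboxylic acid at that same place would behave in this assay.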